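Isobutyl to cyclopropyl on the aromatic nitrogen

The source may report more compounds than this note shows. Statements on the series, on what has been measured and on what is new or still open speak of the compounds shown alone.

Measured in an ADME assay on C8166 cells (Homo sapiens) for cytotoxicity, read by MTT assay; a lower number here means that less compound is tolerated, a higher number that more compound is tolerated:
- compound 1 `CC(C)Cn1cc(C(=O)O)c(=O)c2c(O)c(Cc3cccc(Cl)c3F)ccc21`: 19500 nM
- compound 2 `CC(C)(C)n1cc(C(=O)O)c(=O)c2c(O)c(Cc3cccc(Cl)c3F)ccc21`: 400000 nM

Compound 1 stands lowest of the two numbers in this assay, and compound 2 is its nearest neighbour. Compound 3 `O=C(O)c1cn(C2CC2)c2ccc(Cc3cccc(Cl)c3F)c(O)c2c1=O` has not yet been measured. It keeps the core of compound 1 and carries cyclopropyl in place of isobutyl on an aromatic nitrogen.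

For the measured compounds named here, only one measured step bears on this change: a 21-fold higher number from compound 1 to compound 2 (1.31 log units; beyond the scatter). This step is large and beyond the scatter, and it also replaces isobutyl, there with tert-butyl. It is a single step with a different entering group, so it gives the direction only loosely and does not fix the size. Going by the values given here, a step towards a higher number is expected, smaller than the one seen with compound 2 and possibly not clear of the scatter.

For compound 3 the expected value is 60000 nM, with an estimated range of 15000 nM to 250000 nM. The estimate amounts to a 3.1-fold higher number from compound 1 to compound 3 (0.49 log units; beyond the scatter).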

Compound 3, half-maximal cytotoxic concentration: 39100 nM
Beside the measured number, compound 3's estimate is 1.5-fold (0.19 log units) above it; the measured number falls inside the stated range.
By their numbers in this assay, from the lowest: compounds 1 and 3 (each within the scatter of the next); then compound 2.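

In this assay, cyclopropyl in place of isobutyl on the aromatic nitrogen gives a 2.0-fold higher number from compound 1 to compound 3 (0.30 log units; within the scatter) and so does not separate the two groups at this position. Cyclopropyl in place of tert-butyl gives a 10-fold lower number from compound 2 to compound 3 (1.01 log units; beyond the scatter) and leaves compound 2 alone at the high end of the three, which the single step from isobutyl to tert-butyl could not show. Within these three compounds, a ring on the nitrogen does not set cyclopropyl apart from open-chain isobutyl, and the large steps at this position are the two that involve tert-butyl.

Open, as far as these compounds go, is whether cyclobutyl, or a longer chain such as n-pentyl or 2-hydroxyethyl, on this nitrogen would stay with compounds 1 and 3 or move towards compound 2. Also open, from the compounds shown here alone, is whether the large gap to the tert-butyl compound would persist with an amide in place of the carboxylic acid on the shared core. No measurement available here gives a reason for the standing of any of these groups.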